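This account rests on a few compounds, and the source may have more. Where it says the series, first, only, none or still open, it means among the compounds named here.

In an ADME assay on NIH3T3 cells (Mus musculus) for cytotoxicity, with a stated time of 72 h (on this read-out higher numbers stand for weaker inhibition and lower numbers for stronger inhibition), compounds sharing one core have been measured, and they differ in the aromatic group on the saturated chain carbon. Compound 1 (`OC[C@H]1O[C@@H](n2cnc3c(NCc4ccccc4Cl)ncnc32)[C@H](O)[C@@H]1O`) reads > 166000 nM, which is a limit of the assay. Compound 2 (`Cc1cccc(CNc2ncnc3c2ncn3[C@@H]2O[C@H](CO)[C@@H](O)[C@H]2O)c1`) reads > 166000 nM, which is also a limit. For the measured compounds named here, compound 3 (`COc1ccccc1CNc1ncnc2c1ncn2[C@@H]1O[C@H](CO)[C@@H](O)[C@H]1O`) gives 140000 nM, the only actual number in the set. The other two readings sit at the limit of > 166000 nM in this assay, at which 2 of the 3 values shown sit.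

Compound 4 (`COc1cccc(CNc2ncnc3c2ncn3[C@@H]2O[C@H](CO)[C@@H](O)[C@H]2O)c1`) has 3-methoxyphenyl in place of 2-methoxyphenyl on a saturated chain carbon bound to a nitrogen on an aromatic ring. Its atoms are the same as those of compound 3, joined differently.

Going by the values given here, two measured steps bear on this change. One is an at least 1.1-fold lower number from compound 1 to compound 3 (0.07 log units; that floor lies within the scatter), and the other, which also involves a 3-methylphenyl group, is an at least 1.1-fold lower number from compound 2 to compound 3 (0.07 log units; that floor lies within the scatter). Neither floor goes beyond the scatter, and a step that the two limits leave unreadable from compound 1 to compound 2 adds nothing of readable size. In this assay, no step beyond the scatter is therefore expected, and a reading at the limit would not be surprising. The expected step is a 1.1-fold higher number from compound 3 to compound 4 (0.03 log units; within the scatter). For compound 4 the estimated value is 150000 nM, with an expected range from 90000 nM to 260000 nM.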

Compound 4, half-maximal inhibitory concentration: > 166000 nM
Compound 4: only a limit was reported; the forecaster's own chance of this, stated with the estimate: 45%; middle value at least 1.1-fold (0.04 log units) away from the limit.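

In this assay, 3-methoxyphenyl in place of 2-methoxyphenyl on a saturated chain carbon bound to a nitrogen on an aromatic ring gives an at least 1.1-fold higher number from compound 3 to compound 4 (0.07 log units; that floor lies within the scatter), the first direct test of where the methoxy group sits, although this floor does not establish a real difference between the two isomers. On these data alone, the reading for compound 4 is a limit and not a number, so the actual size of this step remains unknown, and the steps linking compound 1, compound 2 and compound 4 cannot be read at all. The 3-methoxyphenyl group thus joins 2-chlorophenyl and 3-methylphenyl at the same reported ceiling, leaving compound 3 as the only compound with an actual number, and that number is not shown to differ beyond the scatter from any of the others: the limit of > 166000 nM in this assay, at which 3 of the 4 values shown sit.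

The compounds shown leave open how far compound 1, compound 2 and compound 4 lie from one another, since their readings give no numbers to compare. They also leave open whether a hydroxy group, an amine or a carboxylic acid in place of the methoxy on the aromatic carbon would give a step beyond the scatter in this assay.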